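The source may hold more compounds than are shown below. What is called first, only, known or untested is meant among the compounds shown, and "the series" means these compounds.

The measured compounds:
Compound 1 `C/C(=C\c1cc(-c2ccccc2)cs1)C(N)=O` gives in a functional assay on T-24 cells (Homo sapiens) for cytotoxicity, read by CCK-8 assay, with a stated time of 24 h (a lower number here means a stronger inhibitor, a higher number a weaker inhibitor), a reading of > 50000 nM, which is a limit of the assay and not a number.
Compound 2 `C/C(=C\c1cc(-c2ccc(F)cc2)cs1)C(N)=O` gives in this assay a reading of > 50000 nM, again a limit.
Compound 3 `C/C(=C\c1cccc(-c2ccc(C)cc2)c1)C(N)=O` gives in this assay a reading of 7650 nM.

Compound 2 therefore stands at the edge of what this assay reports, as described by the limit of > 50000 nM in this assay, at which 2 of the 3 values shown sit. For the measured compounds named here, the one measured step that touches it, a step that the two limits leave unreadable from compound 1 to compound 2, cannot be sized because the limit of > 50000 nM in this assay, at which 2 of the 3 values shown sit, covers both of its ends. Compound 4 `C/C(=C\c1cc(-c2ccc(S(C)(=O)=O)cc2)cs1)C(N)=O` differs from compound 2 in one place: methylsulfonyl in place of fluoro on an aromatic carbon. Going by the values given here, no measured step shows a methylsulfonyl entering anywhere, so nothing among the measured compounds gives the size or direction of this change; compound 3, the only one with a number, differs from compound 2 in its core as well and cannot be read as a single step. No step beyond the scatter is expected from compound 2 to compound 4, a step that the limit leaves unreadable from compound 2 to compound 4, and the most likely outcome is that the assay again reports only a limit. Compound 4 is therefore estimated at 60000 nM, within 15000 nM to 200000 nM.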

Compound 4, half-maximal inhibitory concentration: > 50000 nM
Compound 4: only a limit was reported (the forecaster's own chance of this, stated with the estimate: 75%); the middle value lies beyond the limit too.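

In this assay compound 4 gives > 50000 nM, a limit of the assay and not a number. Its steps from compound 1 and from compound 2 cannot be read, because both ends of each step sit at the same limit: the limit of > 50000 nM in this assay, at which 3 of the 4 values shown sit.

The compounds shown leave open how far compound 1, compound 2 and compound 4 lie beyond that limit, and whether methylsulfonyl or fluoro changes their activity at all.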